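The compounds below may be only part of what the source reports. "The series", "measured", "known", "first", "only" and "open" are said of these compounds alone.

Compound 1 `CNC(=O)c1cc(Oc2ccc(NC(=O)c3cc4cccnc4n(-c4ccc(F)cc4)c3=O)cc2)ccn1`: 160 nM
Compound 2 `CNC(=O)c1cc(Oc2ccc(NC(=O)c3cc4cccnc4n(-c4ccc(OC)cc4)c3=O)cc2)ccn1`: 920 nM
Compound 3 `CCNC(=O)c1cc(Oc2ccc(NC(=O)c3cc4cccnc4n(-c4ccc(F)cc4)c3=O)cc2)ccn1`: 190 nM

In a functional assay on HT-29 cells (Homo sapiens) for antiproliferative activity, read by MTT assay, with a stated time of 72 h (on this read-out higher numbers stand for weaker inhibition and lower numbers for stronger inhibition), compound 3 gives 190 nM, the second highest of the three numbers. The step of a 1.2-fold higher number from compound 1 to compound 3 (0.07 log units; within the scatter) is within the scatter, whereas compound 2 sits beyond it. Compound 4 `CCNC(=O)c1cc(Oc2ccc(NC(=O)c3cc4cccnc4n(-c4ccc(F)c(Cl)c4)c3=O)cc2)ccn1` differs from compound 3 by chloro in place of hydrogen on an aromatic carbon, that is 4-fluorophenyl to 3-chloro-4-fluorophenyl. Within the data shown here, no measured step adds a chloro group anywhere. Among the measured compounds shown here, the only step on this ring, a 5.8-fold higher number from compound 1 to compound 2 (0.76 log units; beyond the scatter), shows that a change at this ring can move the number by a modest amount; the step on the amide end says nothing about it. For compound 4 the expected step is therefore a 1.1-fold higher number from compound 3 to compound 4 (0.02 log units; within the scatter), with wide uncertainty. Compound 4 is estimated at 200 nM, range 70 nM to 600 nM.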

Compound 4, half-maximal inhibitory concentration: 2600 nM
The estimate for compound 4 lay 13-fold (1.11 log units) below the measured number, and the stated range ends below it.
By their numbers in this assay, from the lowest: compounds 1 and 3 (each within the scatter of the next); then compound 2; then compound 4.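

In this assay chloro in place of hydrogen, ortho to the fluoro group, brings a 14-fold higher number from compound 3 to compound 4 (1.14 log units; beyond the scatter) and marks this aromatic carbon as sensitive to the addition of a single chlorine atom. Among these compounds, the earlier compounds showed only that replacing the fluoro group itself could raise the number; this is the first change at a ring carbon that carried hydrogen. Nothing available explains the rise. The compounds shown leave open whether fluoro, methyl or an amine on this same carbon would give a similar step. Also open, on these data alone, is whether chloro there would act the same way without the fluoro group.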